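Moving the Bromine Around the Ring of a Hydrazone

The compounds below may be only part of what the source reports. "The series", "measured", "known", "first", "only" and "open" are said of these compounds alone.

Compound 3 `O=C(COc1cccc2ccccc12)N/N=C/c1cccc(Br)c1` was tested in an ADME assay on MT4 cells (Homo sapiens) for cytotoxicity, read by MTT assay, with a stated time of 4 days (a higher number here means that more compound is tolerated, a lower number that less compound is tolerated), and gives 87.4 ug/mL. Among the three measured compounds this is the second highest number. Compound 1 `O=C(COc1cccc2ccccc12)N/N=C/c1ccc(Cl)cc1` gives 87.6 ug/mL, and the two sit within the scatter, while compound 2 `O=C(COc1cccc2ccccc12)N/N=C/c1ccccc1O` gives 5.19 ug/mL, so that a 17-fold higher number from compound 2 to compound 3 (1.23 log units; beyond the scatter) is a large step. Compound 4 `O=C(COc1cccc2ccccc12)N/N=C/c1ccc(Br)cc1` differs from compound 3 in one place: 4-bromophenyl in place of 3-bromophenyl on a carbon with a double bond to nitrogen. Within the data shown here, the only measured step that bears on this is a 1.0-fold lower number from compound 1 to compound 3 (0.00 log units; within the scatter), which also changed only the phenyl group on the carbon with a double bond to nitrogen and moved nothing beyond the scatter. No step beyond the scatter is therefore expected in this assay. Compound 4 is expected to give 85 ug/mL, with a range from 45 ug/mL to 170 ug/mL. The expected step is a 1.0-fold lower number from compound 3 to compound 4 (0.01 log units; within the scatter).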

Compound 4, half-maximal cytotoxic concentration: 106 ug/mL
Beside the measured number, compound 4's estimate is 1.2-fold (0.10 log units) below it; the measured number falls inside the stated range.
By their numbers in this assay, from the lowest: compound 2; then compounds 3, 1 and 4 (each within the scatter of the next).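

Moving the bromine to give the 4-bromophenyl group changes nothing that can be told apart in this assay (a 1.2-fold higher number from compound 3 to compound 4 (0.08 log units; within the scatter)), so the two bromophenyl groups cannot be separated at this place. Bromo in place of chloro on the aromatic carbon also stays within the scatter (a 1.2-fold higher number from compound 1 to compound 4 (0.08 log units; within the scatter)), while the large gap to the 2-hydroxyphenyl group remains (a 20-fold higher number from compound 2 to compound 4 (1.31 log units; beyond the scatter)). Nothing available explains any of these numbers.

From the compounds shown here alone, whether the low number of compound 2 belongs to the hydroxyl group alone stays open. So does what an amine or a carboxylic acid on the phenyl ring would give.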